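The source may hold more compounds than are shown below. What is called first, only, known or untested is meant among the compounds shown, and "the series" means these compounds.

Compound 1 `O=C(NOCc1ccccc1F)c1cn(-c2ccccc2)nc1-c1ccccc1` gave 5940 nM in a functional assay on A549 cells (Homo sapiens) for antiproliferative activity, read by MTT assay, with a stated time of 48 h, in the presence of a further agent that is not named here; on this read-out lower numbers stand for stronger inhibition of growth and higher numbers for weaker inhibition of growth; compound 2 `O=C(NOCc1ccccc1F)c1cn(-c2ccccc2)nc1-c1ccc(Cl)cc1` gave 12100 nM; compound 3 `O=C(NOCc1ccccc1Cl)c1cn(-c2ccccc2)nc1-c1ccc(F)cc1` gave 8330 nM.

The change from compound 1 to compound 2 is chloro in place of hydrogen on an aromatic carbon, and it produced a 2.0-fold higher number from compound 1 to compound 2 (0.31 log units; beyond the scatter). Compound 4 `O=C(NOCc1ccc(Cl)cc1Cl)c1cn(-c2ccccc2)nc1-c1ccc(F)cc1` has not yet been tested in this assay. It differs from compound 3 by chloro in place of hydrogen on an aromatic carbon. The difference between the core of compound 1 and the core of compound 3 is not broken down here. The two changes are of the same kind, though not the same: in compound 4 the entering chloro stands meta to a chloro group as well as para to a large group, whereas in compound 2 it stands only para to a large group. On the strength of a 2.0-fold higher number from compound 1 to compound 2 (0.31 log units; beyond the scatter), compound 4 is expected to show a step of a 1.7-fold higher number from compound 3 to compound 4 (0.23 log units; within the scatter). Compound 4 is thus estimated at 14000 nM, between 6000 nM and 32000 nM.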

Compound 4, concentration for 50% growth inhibition: 14000 nM
Compound 4: middle estimate and measured number agree at the digits printed, and the stated range covers the measured number.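

In this assay, chloro in place of hydrogen on an aromatic carbon gave a 1.7-fold higher number from compound 3 to compound 4 (0.23 log units; within the scatter). Set beside the earlier step, the same change on the other core gave a result that does not differ: the same change on two cores in this assay, a 2.0-fold higher number (0.31 log units; beyond the scatter) from compound 1 to compound 2 and a 1.7-fold higher number (0.23 log units; within the scatter) from compound 3 to compound 4, 1.2-fold (0.08 log units) apart, within the scatter of two such steps This shows that the change carried over between these two cores with a similar size, even though in compound 4 the chloro stands meta to a chloro group, but it shows nothing about other cores, and the step to compound 4 taken alone lies within the scatter.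

The compounds shown leave open whether a methoxy group, an amine or a carboxylic acid at that place would give a step like that of chloro. They also leave open whether the step would hold on a core without a fluoro or chloro group.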